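The source may report more compounds than this note shows. Statements on the series, on what has been measured and on what is new or still open speak of the compounds shown alone.

Measured so far:
compound 1 `O=c1c2ccccc2nc(CO[N+](=O)[O-])n1NS(=O)(=O)c1ccccc1` — 55%
compound 2 `Cc1nc2ccccc2c(=O)n1NS(=O)(=O)c1ccccc1` — 77.3%
compound 3 `O=C(NC1CCCCC1)Nn1c(CO[N+](=O)[O-])nc2ccccc2c1=O` — 80.6%

In a functional assay on the whole organism (strain Sprague-Dawley) for inhibition, with Rattus norvegicus as the target, read by paw edema, with stated times of 30 min and 3 h, at a dose of 80 mg/kg by the oral route (a higher number here means more inhibition at the dose given (going by the name of the read-out), a lower number less inhibition), compound 1 gives the lowest of the three numbers; compound 2 and compound 3 both stand higher than compound 1 by more than the scatter. Within the data shown here, the one measured step, a number 22.3 percentage points higher from compound 1 to compound 2 (beyond the scatter), concerns the nitrooxy group on the chain, a place left untouched in compound 4 `CC(=O)Nc1ccc(S(=O)(=O)Nn2c(CO[N+](=O)[O-])nc3ccccc3c2=O)cc1`. Compound 4 differs from compound 1 as acetamido in place of hydrogen on an aromatic carbon. Among the measured compounds shown here, no measured step touches the ring that is changed here, so there is no basis for expecting a step beyond the scatter in either direction. Compound 4 is therefore expected to give 60%, with a range from 40% to 80%. The estimated step is then a number 5 percentage points higher from compound 1 to compound 4 (within the scatter).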

Compound 4, a percentage reported as inhibition, in the whole organism at one dose (the size of the read-out at that dose, not a potency): > 100%
Compound 4: only a limit was reported; the forecaster's own chance of this, stated with the estimate: 0%; middle value at least 40 percentage points away from the limit.
By their numbers in this assay, from the lowest: compound 1; then compounds 2 and 3 (each within the scatter of the next). At a limit, above all of these: compound 4.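

Changing the six-membered aromatic ring of carbon only, at the place para to a large group, can clearly move this read-out: in this assay acetamido in place of hydrogen there brings a number at least 45 percentage points higher from compound 1 to compound 4 (beyond the scatter) as the result of this single change. Compound 4 gives > 100% as a limit of the assay and not as a number. From the compounds shown here alone, whether an amine or a carboxylic acid at this place would also raise the number stays open. So does whether acetamido would do the same on compound 2, which lacks the nitrooxy group.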